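The source may hold more compounds than are shown below. What is called first, only, known or untested is meant among the compounds shown, and "the series" means these compounds.

Series notes, adenosine receptor A3 displacement.

Compound 1 `CONc1nc(C#CCCCC#N)nc2c1ncn2[C@@H]1O[C@H](CO)[C@@H](O)[C@H]1O` gives 4.1 nM in an assay on CHO cells for displacement of a labelled ligand from adenosine receptor A3 (Homo sapiens); a higher number here means a weaker inhibitor, a lower number a stronger inhibitor. Compound 2 `CONc1nc(C#Cc2cccc(C(F)(F)F)c2)nc2c1ncn2[C@@H]1O[C@H](CO)[C@@H](O)[C@H]1O` gives 23 nM; the change 3-(trifluoromethyl)phenyl in place of 3-cyanopropyl on a triple-bonded carbon brings a 5.6-fold higher number from compound 1 to compound 2 (0.75 log units; beyond the scatter). Compound 3 `CCNC(=O)[C@H]1O[C@@H](n2cnc3c(NOC)nc(I)nc32)[C@H](O)[C@@H]1O` gives 2.8 nM, the smallest of the three numbers; compound 1 sits within the scatter of it, and compound 2 lies beyond the scatter.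

Compound 4 `CCNC(=O)[C@H]1O[C@@H](n2cnc3c(NOC)nc(C#Cc4ccc(C)cc4)nc32)[C@H](O)[C@@H]1O` has not yet been measured. It differs from compound 3 by 2-(4-methylphenyl)ethynyl in place of iodo on an aromatic carbon, the site being part of a fused or bridged system of two rings, between two ring nitrogen atoms, meta to a methoxyamino group.

Within the data shown here, no measured step replaces iodo with an arylethynyl group. Among the measured compounds shown here, the one step available, a 5.6-fold higher number from compound 1 to compound 2 (0.75 log units; beyond the scatter), only compares two substituents on a triple-bonded carbon and shows that an aryl group there can cost affinity. For the measured compounds named here, compound 2, the only measured arylethynyl compound, gives 23 nM; compound 3 gives 2.8 nM. A modest rise in the number is therefore expected, a 4.3-fold higher number from compound 3 to compound 4 (0.63 log units; beyond the scatter), though the range is wide. For compound 4 the estimate is 12 nM, with 3 nM to 50 nM.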

Compound 4, inhibition constant: 6.8 nM
Compound 4: the middle estimate sits 1.8-fold (0.25 log units) above what was measured, within the range that was stated.
By their numbers in this assay, from the lowest: compounds 3, 1 and 4 (each within the scatter of the next, the first and the last beyond it); then compound 2.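

In this assay, the aromatic carbon between two ring nitrogen atoms, meta to a methoxyamino group, accepts 2-(4-methylphenyl)ethynyl in place of iodo with a 2.4-fold higher number from compound 3 to compound 4 (0.39 log units; beyond the scatter). The step is modest even though 1 heavy atom leaves and 9 heavy atoms enter, including one six-membered aromatic ring of carbon only and a triple bond, so this site on the shared core tolerates a much larger group at only a modest cost in this assay. The earlier step compared only two substituents on a triple-bonded carbon, whereas this one changes the atom attached directly to the aromatic carbon, and nothing available explains its size.

Still open, going by these compounds, is how the triple-bonded position responds on this ethyl amide core to other groups, such as a primary amine on a longer chain or a carboxylic acid on the phenyl ring. No pair shown differs only in the ethyl amide against the hydroxymethyl group, so the effect of that change on the number cannot be read.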